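Bromo in place of chloro in compound 4

A few compounds are considered here, and "the series" means these few. Any claim that something is new, unique, unknown or untested is made for them only; others in the source may bear on it.

In a functional assay on MCF7 cells (Homo sapiens) for antiproliferative activity, read by MTT assay, with a stated time of 24 h (a higher number here means a weaker inhibitor, a lower number a stronger inhibitor), compound 3 `O=S(=O)(c1ccc(Cl)cc1)n1c(-c2cn(-c3ccccc3)nc2-c2ccc(F)cc2)nc2ccccc21` gives 4960 nM. Compound 2 `Cc1ccc(C)c(S(=O)(=O)n2c(-c3cn(-c4ccccc4)nc3-c3ccc(F)cc3)nc3ccccc32)c1` gives a much lower 430 nM, while compound 1 `Cc1ccc(-c2nn(-c3ccccc3)cc2-c2nc3ccccc3n2S(=O)(=O)c2ccc(Br)cc2)cc1`, which also carries 4-bromophenyl on its sulfonyl sulfur but differs elsewhere, gives 3160 nM, within the scatter of compound 3. Compound 4 `O=S(=O)(c1ccc(Br)cc1)n1c(-c2cn(-c3ccccc3)nc2-c2ccc(F)cc2)nc2ccccc21` has bromo in place of chloro on an aromatic carbon. For the measured compounds named here, the only measured step at this sulfonyl group, a 12-fold higher number from compound 2 to compound 3 (1.06 log units; beyond the scatter), was large, but it exchanged 2,5-dimethylphenyl for 4-chlorophenyl, not one halogen for another. No shift beyond the scatter is therefore expected in this assay, and the expected change is a 1.2-fold lower number from compound 3 to compound 4 (0.07 log units; within the scatter). For compound 4 the estimated value is 4200 nM, with an expected range of 1900 nM to 9000 nM.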

Compound 4, half-maximal inhibitory concentration: 2630 nM
Compound 4: the middle estimate sits 1.6-fold (0.20 log units) above what was measured, and the stated range covers the measured number.
By their numbers in this assay, from the lowest: compound 2; then compounds 4, 1 and 3 (each within the scatter of the next).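

In this assay, the exchange of chloro for bromo gives a 1.9-fold lower number from compound 3 to compound 4 (0.28 log units; within the scatter), so these two halogens are not told apart at this position. The 2,5-dimethylphenyl group of compound 2 also stands apart from the 4-bromophenyl group, with a 6.1-fold higher number from compound 2 to compound 4 (0.79 log units; beyond the scatter), so its gap is not confined to the chloro compound. Elsewhere on the shared core, fluoro in place of methyl gives a 1.2-fold lower number from compound 1 to compound 4 (0.08 log units; within the scatter) and likewise stays within the scatter.

The compounds shown offer no measurement that explains these numbers. From the compounds shown here alone, whether an amine or a carboxylic acid in place of the halogen would shift the number stays open.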